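This account rests on a few compounds, and the source may have more. Where it says the series, first, only, none or still open, it means among the compounds named here.

Measured compounds:
compound 1 `CC(/C=C/CC(C)CCCC(C)C)=C\C(=O)OCC(C)C` — 7.69
compound 2 `COC(C)(C)CCCC(C)C/C=C/C(C)=C/C(=O)OCCC(C)C` — 7.03
compound 3 `CCOC(=O)/C=C(C)/C=C/CC(C)CCC(SCC)C(C)C` — 6.9

In a physicochemical assay for lipophilicity (a higher number here means a more lipophilic compound, a lower number a more polar compound), compound 1 gives the highest of the three numbers, with compound 2 lower by a margin beyond the scatter and compound 3 lower still, also beyond the scatter. For the measured compounds named here, no single-point step between measured compounds is available, so the change to compound 4 `CCCC(=O)/C=C(C)/C=C/CC(C)CCCC(C)C` has no measured precedent. The difference is propyl in place of isobutoxy on a carbonyl carbon, or, cut one bond further out, isobutoxycarbonyl to propylcarbonyl. With fewer heavy atoms entering than leaving, a downward step in this assay is expected, of a size beyond the scatter. Compound 4 is estimated at 6.8 (range 6.3 to 7.3), an expected step of a number 0.89 log units lower from compound 1 to compound 4 (beyond the scatter).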

Compound 4, partition coefficient: 6.81
The estimate for compound 4 lay 0.01 log units below the measured number; the range from low to high includes it.
By their numbers in this assay, from the lowest: compounds 4, 3 and 2 (each within the scatter of the next); then compound 1.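

In this assay, for the compounds shown here, propyl in place of isobutoxy on a carbonyl carbon gives the first single-place step, a number 0.88 log units lower from compound 1 to compound 4 (beyond the scatter). This position therefore responds to this change by more than the scatter, a point compounds 2 and 3 could not establish. No available evidence accounts for the step.

Going by these compounds alone, the single step does not separate the loss of the oxygen from the drop in heavy atoms. As far as these compounds go, the effect of an amine or a longer chain on this carbonyl carbon in this assay remains open.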